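Oxadiazole methyl to isopropyl: working notes on the series

The source may report more compounds than this note shows. Statements on the series, on what has been measured and on what is new or still open speak of the compounds shown alone.

Measured so far in a functional assay on MIA PaCa-2 cells (Homo sapiens) for inhibition, read by MTT assay, with a stated time of 3 days; on this read-out lower numbers stand for stronger inhibition and higher numbers for weaker inhibition
- compound 1 `CCN(CC)S(=O)(=O)c1ccc(S(=O)(=O)N2CCC[C@@H](C(=O)NC3CN(C(=O)NC(C)(C)C)C3)C2)cc1` gives 1400 nM
- compound 2 `CC(C)c1noc(N2CCN(C(=O)[C@@H]3CCCN(S(=O)(=O)c4ccc(S(=O)(=O)NC(C)(C)C)cc4)C3)CC2)n1` gives 100 nM
- compound 3 `CCN(CC)S(=O)(=O)c1ccc(S(=O)(=O)N2CCC[C@@H](C(=O)N3CCN(c4nc(C)no4)CC3)C2)cc1` gives 200 nM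

Of these numbers, compound 3 at 200 nM lies within the scatter of compound 2 at 100 nM and clearly under compound 1 at 1400 nM in this assay. The next structure is compound 4 `CCN(CC)S(=O)(=O)c1ccc(S(=O)(=O)N2CCC[C@@H](C(=O)N3CCN(c4nc(C(C)C)no4)CC3)C2)cc1`, which has isopropyl in place of methyl on an aromatic carbon. In other words, 3-methyl-1,2,4-oxadiazol-5-yl becomes 3-isopropyl-1,2,4-oxadiazol-5-yl.

Among the measured compounds shown here, the only measured single-place step is a 7.0-fold lower number from compound 1 to compound 3 (0.85 log units; beyond the scatter). It is a modest step, but it exchanges the whole group on the carbonyl carbon and does not test the substituent on the oxadiazole. Compound 2 does carry 3-isopropyl-1,2,4-oxadiazol-5-yl and gives 100 nM, though the rest of compound 2 is not identical to compound 4. For the measured compounds named here, no measured pair isolates this change, so the evidence is indirect. A large move is not expected, and any shift in this assay should stay within the scatter, slightly towards lower numbers if anything. The estimated change is a 1.5-fold lower number from compound 3 to compound 4 (0.19 log units; within the scatter) for now. Compound 4 is expected at 130 nM in this assay, with an estimated range from 50 nM to 350 nM.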

Compound 4, half-maximal inhibitory concentration: 30 nM
Estimate against measurement, compound 4: 4.3-fold (0.64 log units) above, and the stated range ends above it.
By their numbers in this assay, from the lowest: compound 4; then compounds 2 and 3 (each within the scatter of the next); then compound 1.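

In this assay, the substituent on the oxadiazole matters on its own: with the rest of the structure held constant, isopropyl in place of methyl on an aromatic carbon, between two ring nitrogen atoms, gives a 6.7-fold lower number from compound 3 to compound 4 (0.82 log units; beyond the scatter). The earlier single-place step exchanged the whole group on the carbonyl carbon, whereas the new pair with 3-isopropyl-1,2,4-oxadiazol-5-yl held fixed shows that the sulfonyl sulfur is a second responsive place, where diethylamino in place of (tert-butyl)amino gives a 3.3-fold lower number from compound 2 to compound 4 (0.52 log units; beyond the scatter). Nothing measured here bears on the reason for either step.

On these data alone, whether the trend continues past isopropyl on this aromatic carbon stays open, for instance with tert-butyl, cyclopropyl, a longer chain or a chain ending in an amine. Also open, as far as these compounds go, is whether the step from methyl to isopropyl keeps its size with (tert-butyl)amino on the sulfonyl sulfur, since only the diethylamino pair reads this change directly.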